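The Benzyloxycarbonylamino Variant at the Lipophilicity Ceiling

The source may hold more compounds than are shown below. What is called first, only, known or untested is meant among the compounds shown, and "the series" means these compounds.

Compound 1 `Cc1cc(C(=O)NC(C)C)nn1Cc1cc(Cl)ccc1OCc1ccccc1` was examined in a physicochemical assay for lipophilicity, at pH 7.4; on this read-out lower numbers stand for lower lipophilicity and higher numbers for higher lipophilicity. In this read-out compound 1 gives only a limit, > 3.7, and not a number. Its two measured neighbours stand at the same ceiling. Compound 2 `Cc1cc(C(=O)Nc2ccccn2)nn1Cc1cc(Cl)ccc1OCc1ccccc1` gives in this assay a limit, > 3.7. Compound 3 `Cc1cc(NC(=O)C2CCOCC2)nn1Cc1cc(Cl)ccc1OCc1ccccc1` gives in this assay a limit as well, > 3.7. Within the data shown here, because of the limit of > 3.7 in this assay, at which 3 of the 3 values shown sit, none of the measured steps has a readable size: a step that the two limits leave unreadable from compound 1 to compound 2, a step that the two limits leave unreadable from compound 1 to compound 3 and a step that the two limits leave unreadable from compound 2 to compound 3.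

Compound 4 `Cc1cc(NC(=O)OCc2ccccc2)nn1Cc1cc(Cl)ccc1OCc1ccccc1` is the next member of the series. It differs from compound 1 in one place: (benzyloxycarbonyl)amino in place of isopropylcarbamoyl on an aromatic carbon. Among the measured compounds shown here, no measured step bears on this change with a size that can be read, since every neighbour of compound 1 gives only a limit. Because compound 1 already sits at the limit of > 3.7 in this assay, at which 3 of the 3 values shown sit, compound 4 is expected to stay at that ceiling, with an expected step that the limit leaves unreadable from compound 1 to compound 4 that the measured pairs cannot confirm. The estimate for compound 4 in this assay is 4.6, ranging from 3.9 to 5.3.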

Compound 4, distribution coefficient: 3.1
Beside the measured number, compound 4's estimate is 1.50 log units above it, and the stated range ends above it.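

At this aromatic carbon, next to the ring nitrogen, the series now gives a readable number in this assay: (benzyloxycarbonyl)amino in place of isopropylcarbamoyl gives a number at least 0.60 log units lower from compound 1 to compound 4 (beyond the scatter). The same group in place of (pyridin-2-yl)carbamoyl gives a number at least 0.60 log units lower from compound 2 to compound 4 (beyond the scatter), and benzyloxy in place of oxan-4-yl on the carbonyl carbon gives a number at least 0.60 log units lower from compound 3 to compound 4 (beyond the scatter). Compound 4 carries more heavy atoms than compound 1 and an added aromatic ring, yet it alone comes off the ceiling, while the steps among the other compounds still cannot be read: the limit of > 3.7 in this assay, at which 3 of the 4 values shown sit.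

From the compounds shown here alone, the full size of these steps stays open, as does whether the lower value goes with the benzyloxy group or with the carbonylamino link. Where a methoxy or a tert-butoxy on that carbonyl carbon, or a plain amine on the aromatic carbon, would stand in this assay also remains open.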